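A few compounds are considered here, and "the series" means these few. Any claim that something is new, unique, unknown or untested is made for them only; others in the source may bear on it.

Measured so far:
compound 1, `NCC(O)Cn1c(=O)n(C2OC(CO)[C@@H](O)[C@H]2O)c2nc(N)nc(O)c21`, 110%
compound 2, `Nc1nc(O)c2c(n1)n(C1OC(CO)[C@@H](O)[C@H]1O)c(=O)n2CC(O)CSc1ccccc1`, 12%
compound 3, `Nc1nc(O)c2c(n1)n(C1OC(CO)[C@@H](O)[C@H]1O)c(=O)n2Cc1ccc(Cl)cc1`, 15%

In a functional assay on the whole organism (B cells) with Mus musculus as the target (on this read-out lower numbers stand for smaller maximal responses and higher numbers for larger maximal responses), compound 1 gives 110%, compound 2 gives 12%, and compound 3 gives 15%. Compound 3 thus sits far below compound 1, while its value and that of compound 2 lie within the usual scatter of each other and cannot be told apart. The step of a number 95 percentage points lower from compound 1 to compound 3 (beyond the scatter) shows how much was lost when 2-amino-1-hydroxyethyl gave way to 4-chlorophenyl; the step of a number 98 percentage points lower from compound 1 to compound 2 (beyond the scatter) shows a loss of the same size for a different large group, and the step of a number 3 percentage points higher from compound 2 to compound 3 (within the scatter) shows that the two large groups behave alike.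

Compound 4, `NC(=O)Cn1c(=O)n(C2OC(CO)[C@@H](O)[C@H]2O)c2nc(N)nc(O)c21`, has not been measured. It differs from compound 3 as follows: carbamoyl in place of 4-chlorophenyl on a saturated chain carbon bound to an aromatic nitrogen. This largely reverses the change from compound 1 to compound 3, putting a short chain with a hydrogen-bond donor and acceptor where the ring was, although carbamoyl is not the same as 2-amino-1-hydroxyethyl. A large rise back toward compound 1 is expected, a number 60 percentage points higher from compound 3 to compound 4 (beyond the scatter), because the step of a number 95 percentage points lower from compound 1 to compound 3 (beyond the scatter) ran the other way. Compound 4 is therefore estimated at 75%, with a range from 25% to 115%.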

Compound 4, largest response reached (reported as maximal response), in percent of the reference or control that the assay uses: 32%
For compound 4 the middle estimate is 43 percentage points above the measured one, and the stated range covers the measured number.
By their numbers in this assay, from the lowest: compounds 2 and 3 (each within the scatter of the next); then compound 4; then compound 1.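

In this assay, carbamoyl on a saturated chain carbon bound to an aromatic nitrogen gives a modest gain over both larger groups, with a number 17 percentage points higher from compound 3 to compound 4 (beyond the scatter) and a number 20 percentage points higher from compound 2 to compound 4 (beyond the scatter). Most of the response still stays out of reach, with a number 78 percentage points lower from compound 1 to compound 4 (beyond the scatter), so replacing 4-chlorobenzyl with the smaller carbamoylmethyl is not enough to restore the response of compound 1. No measurement here explains these differences.

The compounds shown leave open whether the amino group, the hydroxyl group or both in 2-amino-1-hydroxyethyl account for the high response of compound 1. A 2-aminoethyl chain and a 2-hydroxyethyl chain at this position would separate those two groups, while a carboxylic acid on the same carbon would show how the response changes when carbamoyl is replaced.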